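The source may hold more compounds than are shown below. What is called first, only, known or untested is meant among the compounds shown, and "the series" means these compounds.

Working notes on the series. The measured set comprises compound 1 `COc1cccc(CNCCCNc2ccnc3cc(C4CCCCC4)ccc23)c1O`, compound 2 `COc1ccc(F)cc1CNCCCNc1ccnc2cc(C3CCCCC3)ccc12` and compound 3 `c1ccc(Oc2ccc3c(NCCCNCc4ccco4)ccnc3c2)cc1`. In a physicochemical assay for acid dissociation, compound 1 gives 9.47, compound 2 gives 9.47 and compound 3 gives 9.28. Compound 2 stands level with compound 1 at the digits printed, the two together the highest of the three numbers, while its furthest neighbour, compound 3, lies lower by an amount within the scatter, so no order among the three can be read from these data. Going by the values given here, the one single-place step among them, no change at the digits printed from compound 1 to compound 2 (within the scatter), is flat within the scatter.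

Compound 4 `COc1ccc(F)cc1CNCCCNc1ccnc2cc(Oc3ccccc3OC)ccc12` is still to be measured in this assay. It differs from compound 2 as 2-methoxyphenoxy in place of cyclohexyl on an aromatic carbon. Among the compounds with values here, no measured single-place step exchanges a group on this aromatic carbon of the core; compound 3 carries a phenoxy there but also differs elsewhere, so only its value can be set beside that of compound 2, and the two are within the scatter. Within the data shown here, the only step that bears on the question, no change at the digits printed from compound 1 to compound 2 (within the scatter), showed no change, so no step beyond the scatter is expected in this assay for compound 4, a number 0.02 log units lower from compound 2 to compound 4 (within the scatter). For compound 4 a value of 9.45 is estimated, with a range from 9.15 to 9.75.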

Compound 4, acid dissociation constant: 9.28
Beside the measured number, compound 4's estimate is 0.17 log units above it; the range from low to high includes it.
By their numbers in this assay, from the lowest: compounds 3, 4, 1 and 2 (each within the scatter of the next).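

In this assay, going by these compounds alone, the exchange of cyclohexyl for 2-methoxyphenoxy on this aromatic carbon gives a number 0.19 log units lower from compound 2 to compound 4 (within the scatter), the first single-place step at this position of the core. A group of 6 heavy atoms with 0 hydrogen-bond acceptors thus gives way to one of 9 heavy atoms with 2 hydrogen-bond acceptors, and this read-out does not separate the two groups at this place. Nothing available on these compounds offers an explanation for this result.

As far as these compounds go, whether a group such as an amine, a carboxylic acid or a longer chain on this aromatic carbon would give a step beyond the scatter stays open, since only cyclohexyl and 2-methoxyphenoxy have been compared here in a single-place step. Within the data shown here, also open is whether the same flat result would hold with a group other than 5-fluoro-2-methoxyphenyl on the saturated chain carbon bound to an amine nitrogen, as compound 3 differs from compound 4 in more than one place and so supplies no step at this position.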